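Shifting a Methyl on the Benzyl Ring: Cytotoxicity Outlook

This account rests on a few compounds, and the source may have more. Where it says the series, first, only, none or still open, it means among the compounds named here.

Values in an ADME assay on MT4 cells (Homo sapiens) for cytotoxicity, read by MTT assay, with a stated time of 5 days; on this read-out lower numbers stand for higher toxicity in this test and higher numbers for lower toxicity in this test:
Compound 1 `Cc1cc(C)c(Oc2cc(Nc3ccc(C#N)cc3)ncc2C(=O)NCc2cn(CC(N)=O)nn2)c(C)c1`: 24000 nM
Compound 2 `COC(=O)Cn1cc(CNC(=O)c2cnc(Nc3ccc(C#N)cc3)cc2Oc2c(C)cc(C)cc2C)nn1`: 13800 nM
Compound 3 `Cc1cccc(Cn2cc(CNC(=O)c3cnc(Nc4ccc(C#N)cc4)cc3Oc3c(C)cc(C)cc3C)nn2)c1`: 114000 nM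

Compound 3 stands highest of the three measured numbers, which in this assay means the least toxic: a 4.8-fold higher number from compound 1 to compound 3 (0.68 log units; beyond the scatter), and an 8.3-fold higher number from compound 2 to compound 3 (0.92 log units; beyond the scatter). The remaining pair sits close together: a 1.7-fold lower number from compound 1 to compound 2 (0.24 log units; within the scatter).

Compound 4 `Cc1cc(C)c(Oc2cc(Nc3ccc(C#N)cc3)ncc2C(=O)NCc2cn(Cc3ccccc3C)nn2)c(C)c1` differs from compound 3 only in this way: 2-methylphenyl in place of 3-methylphenyl on a saturated chain carbon bound to an aromatic nitrogen. Within the data shown here, no measured step touches this kind of change; the two steps that reach compound 3 replaced quite different groups on the same chain carbon, and both were modest. With the same atoms merely rearranged, the step from compound 3 is expected to be small: a 1.1-fold lower number from compound 3 to compound 4 (0.06 log units; within the scatter), not beyond the scatter. Compound 4 is therefore estimated at 100000 nM, with a range from 40000 nM to 250000 nM.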

Compound 4, half-maximal cytotoxic concentration: >= 164000 nM
Compound 4: a limit, no number; the forecaster's own chance of this, stated with the estimate: 15%; middle value at least 1.6-fold (0.21 log units) away from the limit.
By their numbers in this assay, from the lowest: compounds 2 and 1 (each within the scatter of the next); then compound 3. At a limit, above all of these: compound 4.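

In this assay compound 4 gives a limit, not a number: the limit of >= 164000 nM in this assay, at which 1 of the 4 values shown sits. Moving the methyl from 3-methylphenyl to 2-methylphenyl brings no measurable rise in toxicity, but any fall cannot be claimed either, with an at least 1.4-fold higher number from compound 3 to compound 4 (0.15 log units; that floor lies within the scatter). The 2-methylphenyl group also keeps the wide gap already seen for 3-methylphenyl over the methoxycarbonyl and carbamoyl groups, with an at least 11-fold higher number from compound 2 to compound 4 (1.07 log units; beyond the scatter) and an at least 6.8-fold higher number from compound 1 to compound 4 (0.83 log units; beyond the scatter).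

Going by these compounds, how far compound 4 truly lies past its limit stays open. So does whether an amine or a carboxylic acid on that saturated chain carbon would give numbers this high.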